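The compounds below may be only part of what the source reports. "The series", "measured", "known", "first", "only" and "open" are said of these compounds alone.

Measured compounds in an ADME assay on Raji cells (Homo sapiens) for cytotoxicity, read by luminescence, with a stated time of 72 h; a lower number here means that less compound is needed, a higher number that more compound is needed for the effect:
Compound 1 `CCOC(=O)c1c(-c2cccc(F)c2)[nH]c2cc(OC)ccc2c1=O` gives > 21500 nM, which is a limit of the assay.
Compound 2 `CCOC(=O)c1c(-c2cccc(Cl)c2)[nH]c2cc(OC)ccc2c1=O` gives > 21500 nM, also a limit.
Compound 3 `CCOC(=O)c1c(-c2cccc(-c3ccccc3)c2)[nH]c2cc(OC)c(Cl)cc2c1=O` gives > 21500 nM, again a limit.

All three values sit at the limit of > 21500 nM in this assay, at which 3 of the 3 values shown sit, so no number is known for any of them. The change from compound 2 to compound 1 is fluoro in place of chloro on an aromatic carbon; the step it made, a step that the two limits leave unreadable from compound 2 to compound 1, is left unreadable by the limit of > 21500 nM in this assay, at which 3 of the 3 values shown sit. How the core of compound 3 differs from the core of compound 2 is not broken down here.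

Compound 4 `CCOC(=O)c1c(-c2cccc(-c3ccccc3)c2)[nH]c2cc(OC)c(F)cc2c1=O` is not yet measured. It differs from compound 3 by fluoro in place of chloro on an aromatic carbon. The surroundings differ from the earlier pair: here the aromatic carbon is part of a fused or bridged system of two rings, ortho to a methoxy group, meta to a fused ring and para to a fused ring, whereas in the earlier pair it was meta to a large group. It is therefore the same kind of change, not the same.

Expected step: a step that the limit leaves unreadable from compound 3 to compound 4, resting on a step that the two limits leave unreadable from compound 2 to compound 1 and (the limit of > 21500 nM in this assay, at which 3 of the 3 values shown sit), which give no sign of movement. For compound 4 the estimate in this assay is 30000 nM, most likely reported again only as a limit.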

Compound 4, half-maximal effective concentration: > 21500 nM
Compound 4: no number, only a limit; the forecaster's own chance of this, stated with the estimate: 85%; the middle value does not contradict the limit.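

In this assay compound 4 gives > 21500 nM, which is a limit of the assay and not a number. Compound 3 also stands at a limit, so no step can be read between compound 3 and compound 4: the limit of > 21500 nM in this assay, at which 4 of the 4 values shown sit.

The compounds shown leave open whether fluoro in place of chloro on an aromatic carbon changes the value at all.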